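The compounds below may be only part of what the source reports. "The series", "measured", "known", "first", "only" and "open" are said of these compounds alone.

Compound 1 `Nc1nc(-c2ccc(C(F)F)o2)nc2sc(Cc3ccccc3)cc12` and compound 2 `Cn1cnc(-c2nc(N)c3cc(Cc4ccccc4)sc3n2)c1` share one core and differ only in the group attached to an aromatic carbon of it. In a functional assay on CHO-K1 cells for antagonist activity at adenosine receptor A1 (Homo sapiens), read by a beta-galactosidase reporter and cAMP accumulation, with stated times of 15 min and 6 h (on this read-out lower numbers stand for stronger inhibition and higher numbers for weaker inhibition), compound 1 gives 3000 nM. Compound 2, which carries 1-methyl-1H-imidazol-4-yl in place of 5-(difluoromethyl)furan-2-yl, gives 2330 nM in this assay. Among the compounds with values here, that is the lower of the two numbers known so far, but the step of a 1.3-fold lower number from compound 1 to compound 2 (0.11 log units; within the scatter) does not separate the two compounds. Compound 3 `N#Cc1cccc(-c2nc(N)c3cc(Cc4ccccc4)sc3n2)c1` has not been measured yet; it differs from compound 2 by 3-cyanophenyl in place of 1-methyl-1H-imidazol-4-yl on an aromatic carbon. Within the data shown here, the only measured step, from compound 1 to compound 2, swaps one group at this same carbon and barely moves the number, so the expectation for compound 3 is a step of a 1.6-fold lower number from compound 2 to compound 3 (0.19 log units; within the scatter) that may again stay within the scatter. The estimate for compound 3 is 1500 nM, within 400 nM to 6000 nM.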

Compound 3, inhibition constant: 222 nM
Beside the measured number, compound 3's estimate is 6.8-fold (0.83 log units) above it; the measured number lies below the stated range.
By their numbers in this assay, from the lowest: compound 3; then compounds 2 and 1 (each within the scatter of the next).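

The carbon between two ring nitrogen atoms is not indifferent to the group it carries: in this assay the change to 3-cyanophenyl brings a 10-fold lower number from compound 2 to compound 3 (1.02 log units; beyond the scatter) and a 14-fold lower number from compound 1 to compound 3 (1.13 log units; beyond the scatter). The earlier exchange of 5-(difluoromethyl)furan-2-yl for 1-methyl-1H-imidazol-4-yl stayed within the scatter, so only now is it clear that a change at this carbon can move the number strongly. Nothing measured here bears on why the number falls.

The change brings in a carbon-only six-membered ring and a nitrile together, which leaves open whether the ring, the nitrile or both go with the lower number. A plain phenyl group would separate these two, and an amine or a carboxylic acid in place of the nitrile would test how much that group matters.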